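Acetyl on the hydroxy of compound 1

This account rests on a few compounds, and the source may have more. Where it says the series, first, only, none or still open, it means among the compounds named here.

Values so far in a functional assay on the whole organism for inhibition, with Rattus norvegicus as the target; a higher number here means a weaker inhibitor, a lower number a stronger inhibitor
compound 1 `O=C1ON=C(c2cccs2)/C1=C/c1ccc(O)cc1` gives 4200 nM
compound 2 `COc1ccc(OC)c(C2=NOC(=O)/C2=C\c2cccs2)c1` gives 7900 nM
compound 3 `O=C1ON=C(c2cccs2)/C1=C/c1ccc(O)c(O)c1` gives 3400 nM

Compound 1 lies within the scatter of both other compounds, with compound 3 nearest and compound 2 furthest, so it is not separated from either. Compound 4 `CC(=O)Oc1ccc(/C=C2\C(=O)ON=C2c2cccs2)cc1` has not been measured yet. It differs from compound 1 by acetyl in place of hydrogen on an oxygen on an aromatic ring and the change reads hydroxy to acetoxy, acetyl in place of hydrogen on an oxygen on an aromatic ring. Going by the values given here, only one measured step is available, and it bears on this change only loosely: a 1.2-fold lower number from compound 1 to compound 3 (0.09 log units; within the scatter) is a change on an aromatic carbon and not on that oxygen. Compound 2, which has no hydroxy, gives 7900 nM and also stays within the scatter of compound 1. Among the compounds with values here, no measured compound carries an acetoxy. In this assay, on these data alone, no step beyond the scatter is therefore expected, and the direction stays open. The expected step is a 1.1-fold lower number from compound 1 to compound 4 (0.02 log units; within the scatter) and nothing larger is estimated. Compound 4 is estimated at 4000 nM with an expected range of 1800 nM to 9000 nM.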

Compound 4, half-maximal inhibitory concentration: 4500 nM
The estimate for compound 4 lay 1.1-fold (0.05 log units) below the measured number, within the range that was stated.
By their numbers in this assay, from the lowest: compounds 3, 1, 4 and 2 (each within the scatter of the next, the first and the last beyond it).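

In this assay, acetyl in place of hydrogen on an oxygen on an aromatic ring gives a 1.1-fold higher number from compound 1 to compound 4 (0.03 log units; within the scatter), the first measured change made on that oxygen itself. The free hydroxy of compound 1 can therefore be capped as acetoxy without a step beyond the scatter in this assay, so this assay does not separate the two groups at this position. No measurement bears on why the two compounds are not separated.

Open, on these data alone, is whether a benzoyl group on the same oxygen, or an amine in place of the hydroxy, would give a step beyond the scatter. Also open, as far as these compounds go, is how acetoxy behaves when a second hydroxy, as in compound 3, stands on the same ring.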